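Two Amides at the Edge of the Assay

This account rests on a few compounds, and the source may have more. Where it says the series, first, only, none or still open, it means among the compounds named here.

In an in vitro functional assay on HEK293-A cells for antagonist activity at metabotropic glutamate receptor 5 (Rattus norvegicus), read by calcium flux (a higher number here means a weaker inhibitor, a lower number a stronger inhibitor), compound 1 `COc1ccccc1C(=O)Nc1cccc(NC(=O)c2ccccc2Cl)c1` gives only a limit of > 30000 nM. Compound 2 `COc1ccccc1C(=O)Nc1cccc(NC(=O)c2ccc(Cl)c(Cl)c2)c1` differs from compound 1 only in the aryl group on one carbonyl carbon, and in this assay compound 2 likewise gives only a limit of > 30000 nM. Among the compounds with values here, the single measured step, a step that the two limits leave unreadable from compound 1 to compound 2, therefore cannot be read, since both values sit at the limit of > 30000 nM in this assay, at which 2 of the 2 values shown sit. Compound 2 thus stands where compound 1 stands: at the edge of what this assay reports, with no number of its own.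

Compound 3 `COc1ccccc1C(=O)Nc1cccc(NC(=O)c2cccc(F)c2)c1` carries the next change at the same carbonyl carbon: 3-fluorophenyl in place of 3,4-dichlorophenyl on a carbonyl carbon. Within the data shown here, the only step that bears on it, from compound 1 to compound 2, has no readable size, so it gives no direction to build on. With both measured values resting at the limit, the estimated step of a number no higher from compound 2 to compound 3 (the limit leaves the size open) is taken as none beyond the scatter. Compound 3 is therefore expected to give about 30000 nM in this assay, within a range from 10000 nM to 100000 nM, most likely again as a limit rather than a number.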

Compound 3, half-maximal inhibitory concentration: 6480 nM
Estimate against measurement, compound 3: 4.6-fold (0.67 log units) above; the whole stated range lies above it.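

Within the data shown here, compound 3 is the first of the three to give a number rather than a limit in this assay, which shows that the aryl group on this carbonyl carbon can shift the reading and bring a compound within the range of the assay. Setting 3-fluorophenyl in place of 3,4-dichlorophenyl gives an at least 4.6-fold lower number from compound 2 to compound 3 (0.66 log units; beyond the scatter), and setting it in place of 2-chlorophenyl gives an at least 4.6-fold lower number from compound 1 to compound 3 (0.66 log units; beyond the scatter). Both steps are minimum sizes, not exact ones, and the true gaps may be wider, because the two starting compounds give no number of their own: the limit of > 30000 nM in this assay, at which 2 of the 3 values shown sit.

The compounds leave open which part of the change matters, since 3-fluorophenyl differs from each of the two earlier groups in both the halogen it carries and where that halogen sits, so neither effect can be read alone. As far as these compounds go, it also remains open how this carbonyl carbon would respond to a plain phenyl with no halogen, or to a phenyl carrying an amine or a carboxylic acid.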